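Carbamate aryl variation: iodo for butoxycarbonyl

The source may report more compounds than this note shows. Statements on the series, on what has been measured and on what is new or still open speak of the compounds shown alone.

Three measured carbamates share the methylene lactone core. Compound 1 `C=C1C(=O)OC[C@H]1CCOC(=O)Nc1ccc(C(=O)OCCCC)cc1` gives 430 nM in a functional assay on RAW264.7 cells (Mus musculus) for inhibition, with a stated time of 30 min; on this read-out higher numbers stand for weaker inhibition and lower numbers for stronger inhibition. Compound 3 `C=C1C(=O)OC[C@@H]1CCOC(=O)Nc1cccc(Br)c1` gives 840 nM in this assay, a number within the scatter of compound 1. Compound 2 `C=C1C(=O)OC[C@@H]1CCOC(=O)Nc1c(C)cccc1C(C)C` gives 5980 nM in this assay, the highest of the three and well beyond the scatter from compound 1. Compound 1 thus stands at the lowest number of the set, though not separated from compound 3.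

Compound 4 `C=C1C(=O)OC[C@H]1CCOC(=O)Nc1ccc(I)cc1` is not yet measured. It differs from compound 1 by iodo in place of butoxycarbonyl on an aromatic carbon. For the measured compounds named here, no single-change step between measured compounds covers this kind of exchange, so the expectation leans on compound 3, whose bromo-bearing ring gives 840 nM in this assay. A small step, if any, toward a higher number is expected, with the step from compound 1 to compound 4 estimated at a 1.9-fold higher number from compound 1 to compound 4 (0.27 log units; within the scatter). Compound 4 is expected to give about 800 nM in this assay, within a range of 300 nM to 2500 nM.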

Compound 4, half-maximal inhibitory concentration: 490 nM
Compound 4: middle estimate off by 1.6-fold (0.21 log units), on the high side; the range from low to high includes it.
By their numbers in this assay, from the lowest: compounds 1, 4 and 3 (each within the scatter of the next); then compound 2.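

On an aromatic carbon para to a large group, iodo in place of butoxycarbonyl gives a 1.1-fold higher number from compound 1 to compound 4 (0.06 log units; within the scatter) in this assay. For the compounds shown here, this is the first single-place exchange, and it shows that the full butoxycarbonyl group, with its chain, carbonyl and hydrogen-bond acceptors, is not required for a number at the level of compound 1, since a lone iodo cannot be told apart from it in this read-out. No measurement on hand explains why the two groups read alike.

The compounds shown leave open whether this carbon accepts almost any group or only some, as an amine, a carboxylic acid or a plain hydrogen here would show. They also leave open how far the butyl chain can be shortened or lengthened.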